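The compounds below may be only part of what the source reports. "The series", "measured", "known", "first", "only" and "open" are said of these compounds alone.

Measured compounds:
Compound 1, `CCSC(=S)SCC(=O)c1ccc(S(=O)(=O)Nc2ccc(OC)cc2)cc1`: 4320 nM
Compound 2, `COc1ccc(C(=O)CSC(=S)SCCNC(C)=O)cc1`: 11100 nM

Both compounds were tested in a functional assay on HeLa cells (Homo sapiens) for cytotoxicity, read by resazurin assay, with a stated time of 72 h; on this read-out lower numbers stand for stronger inhibition and higher numbers for weaker inhibition. In this assay compound 1 gives 4320 nM, and compound 2 gives 11100 nM. Among the measured compounds shown here, compound 2 therefore stands at the highest of the two numbers, and the gap to compound 1, its only neighbour, lies beyond the usual scatter. For the measured compounds named here, the two measured compounds differ from each other in several places at once, so no single-point step between measured compounds is available, and nothing measured isolates the change that leads to compound 3.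

Compound 3, `CCCC(=S)SCC(=O)c1ccc(OC)cc1`, has not yet been measured in this assay. It differs from compound 2 in one place: propyl in place of (2-acetamidoethyl)sulfanyl on a thiocarbonyl carbon. Going by the values given here, with no measured step to lean on, the expectation for the step from compound 2 to compound 3 is cautious: a step of a 1.4-fold lower number from compound 2 to compound 3 (0.14 log units; within the scatter) is expected, toward a somewhat lower number, though it may well fall within the scatter. On that basis compound 3 is estimated at 8000 nM in this assay, with a likely range from 2500 nM to 25000 nM.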

Compound 3, half-maximal inhibitory concentration: 5710 nM
For compound 3 the middle estimate is 1.4-fold (0.15 log units) above the measured one; the measured number falls inside the stated range.
By their numbers in this assay, from the lowest: compounds 1, 3 and 2 (each within the scatter of the next, the first and the last beyond it).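

In this assay, among the compounds shown here, the change of (2-acetamidoethyl)sulfanyl to propyl on a thiocarbonyl carbon gives a 1.9-fold lower number from compound 2 to compound 3 (0.29 log units; within the scatter) and is the first single-place comparison in this set. The group that leaves carries 7 heavy atoms, 1 hydrogen-bond donor and 2 hydrogen-bond acceptors, whereas the propyl that enters carries 3 heavy atoms and no donor or acceptor, so in this one pair, removing the sulfur link and the acetamido chain together does not move the reading beyond the scatter. No supporting measurement is available to explain this outcome.

The compounds shown leave open how an amine, a carboxylic acid or a longer alkyl chain on the same thiocarbonyl carbon would read in this assay, and whether any such group would separate from compound 2 by more than the scatter. They also leave open whether the exchange of (2-acetamidoethyl)sulfanyl for propyl would give a similar step on the core of compound 1, or whether this single pair holds only for the core shared by compound 2 and compound 3.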